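A few compounds are considered here, and "the series" means these few. Any claim that something is new, unique, unknown or untested is made for them only; others in the source may bear on it.

Compounds measured so far:
compound 1 `CN(C)CCN(CCN(C)C)c1ccc(C(=O)N2CCc3ccc(OS(N)(=O)=O)cc3C2)cc1`: 3.8%
compound 2 `CCN(Cc1ccccc1)Cc1ccc(CN2CCc3ccc(OS(N)(=O)=O)cc3C2)cc1`: 1%
compound 3 `CCN(Cc1ccc(Br)cc1)c1cccc(C(=O)N2CCc3ccc(OS(N)(=O)=O)cc3C2)c1`: 24.2%

In an assay on HEK293 cells for inhibition of Steryl-sulfatase (Homo sapiens), tested at 0.1 uM (on this read-out higher numbers stand for a stronger effect at the one concentration tested and lower numbers for a weaker effect), compound 3 stands highest of the three; compound 1 lies below it by a margin beyond the scatter, and compound 2 lies further below, again beyond the scatter. Compound 4 `NS(=O)(=O)Oc1ccc2c(c1)CN(C(=O)c1cccc(N3CCc4ccccc4C3)c1)CC2` has not yet been measured in this assay. It differs from compound 3 in one place, (1,2,3,4-tetrahydroisoquinolin-2-yl in place of (4-bromobenzyl)(ethyl)amino on an aromatic carbon), on an aromatic carbon meta to a large group.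

Among the compounds with values here, no step between two measured compounds matches this change, so the expectation rests on the values alone. Compound 4 is expected to fall below compound 3 by a moderate step, estimated as a number 12.2 percentage points lower from compound 3 to compound 4 (beyond the scatter) in this assay. The estimate for compound 4 is 12%, within a range from 2% to 30%.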

Compound 4, a percentage reported as inhibition, at one concentration (the size of the read-out at that concentration, not a potency): 24.1%
Beside the measured number, compound 4's estimate is 12.1 percentage points below it, and the stated range covers the measured number.
By their numbers in this assay, from the lowest: compounds 2 and 1 (each within the scatter of the next); then compounds 4 and 3 (each within the scatter of the next).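

In this assay, putting 1,2,3,4-tetrahydroisoquinolin-2-yl in place of (4-bromobenzyl)(ethyl)amino on an aromatic carbon meta to a large group gives a number 0.1 percentage points lower from compound 3 to compound 4 (within the scatter). This is the first one-place comparison among these compounds, and it shows that, for this pair, the read-out at this position does not depend on keeping the bromine or the open ethyl and benzyl arrangement. Nothing available accounts for this result. As far as these compounds go, whether an unsubstituted amino group or a morpholine ring at this position would give a similar read-out remains open.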